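The compounds below may be only part of what the source reports. "The series", "measured", "known", "first", "only" and "open" are said of these compounds alone.

Measured in an ADME assay on microsomes from liver (Homo sapiens) for metabolic stability, with a stated time of 30 min, tested at 1 uM; a lower number here means that less of the compound is left, a higher number that more of the compound is left:
Compound 1 `Cc1c(Cl)ccc(S(=O)(=O)N(C)CCOCC(=O)N(C)Cc2ccc(C3=NCCN3)cc2)c1Cl`: 8%
Compound 2 `COc1cc(C)c(S(=O)(=O)N(C)CCOCC(=O)N2CCN(C3CCN(C4CC4)CC3)CC2)c(C)c1`: 6%
Compound 3 `COc1cc(C)c(S(=O)(=O)N(C)CCOCC(=O)N2CCC(N3CCN(C(C)C)CC3)CC2)c(C)c1`: 54%

Compound 1, at 8%, cannot be told apart from compound 2, at 6%, while compound 3, at 54%, lies well above both.

The next compound is compound 4 `COc1cc(C)c(S(=O)(=O)N(C)CCOCC(=O)N(C)Cc2ccc(C3=NCCN3)cc2)c(C)c1`. It keeps the rest of compound 1 but carries 4-methoxy-2,6-dimethylphenyl in place of 2,4-dichloro-3-methylphenyl on a sulfonyl sulfur.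

Among the measured compounds shown here, no two measured compounds differ in one place only, so this exchange has no direct precedent. The entering group already occurs in compound 2, at 6%, and in compound 3, at 54%. Those two compounds differ from each other elsewhere, and their values show that this group appears with both a small and a large remainder. It therefore gives little guidance by itself. Everything else in compound 4 is shared with compound 1, which gives 8%, so no change beyond the scatter in this assay is expected, with any shift more likely upward than downward. The expected result is a number 4 percentage points higher from compound 1 to compound 4 (within the scatter). Compound 4 is estimated at 12%, with an expected range of 3% to 30%.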

Compound 4, percent of the compound remaining: 57%
Compound 4: the middle estimate sits 45 percentage points below what was measured, outside the stated range (above it).
By their numbers in this assay, from the lowest: compounds 2 and 1 (each within the scatter of the next); then compounds 3 and 4 (each within the scatter of the next).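

In this assay, putting 4-methoxy-2,6-dimethylphenyl in place of 2,4-dichloro-3-methylphenyl on a sulfonyl sulfur gives a number 49 percentage points higher from compound 1 to compound 4 (beyond the scatter), with the rest of the structure unchanged. Among the compounds shown here, this is the first comparison that differs in one place only, and it shows that the aryl group on the sulfonyl sulfur can, by itself, move the percentage of compound remaining well beyond the scatter. Nothing measured here gives a reason for this rise.

The exchange removes both chlorine atoms, brings in a methoxy group and alters the number of methyl groups all at once, so the compounds shown leave open which of these parts carries the step. Also open, as far as these compounds go, are whether the same exchange would give a step of this size on a different core, and what a plain phenyl or a trifluoromethyl-substituted phenyl would give on the sulfonyl sulfur.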